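This account rests on a few compounds, and the source may have more. Where it says the series, first, only, none or still open, it means among the compounds named here.

Compound 3 `Nc1nc(-c2ccccc2)nc2sc(-c3ccco3)nc12` stands second highest of the three numbers in an assay on CHO cells for displacement of a labelled ligand from adenosine receptor A3 (Homo sapiens), read by scintillation counting, with a stated time of 3 h; a higher number here means a weaker inhibitor, a lower number a stronger inhibitor: compound 3 gives 15 nM, compound 2 `Nc1nc(-c2ccc(CO)cc2)nc2sc(-c3ccccc3)nc12` gives 8.2 nM, within the scatter of it, and compound 1 `Nc1nc(-c2ccccc2)nc2sc(-c3ccccc3)nc12` gives 84 nM, well beyond it. The step of a 5.6-fold lower number from compound 1 to compound 3 (0.75 log units; beyond the scatter) came with furan-2-yl in place of phenyl, and the step of a 10-fold lower number from compound 1 to compound 2 (1.01 log units; beyond the scatter) with hydroxymethyl in place of hydrogen. Compound 4 `Nc1nc(-c2ccc(CO)cc2)nc2sc(-c3ccco3)nc12` applies that second change to compound 3: hydroxymethyl in place of hydrogen on an aromatic carbon. Because the same change gave a 10-fold lower number from compound 1 to compound 2 (1.01 log units; beyond the scatter) on an otherwise unaltered core, a large downward step is expected here too, although compound 2 at 8.2 nM hints that the two changes need not add in full. Compound 4 is therefore expected to give 2.5 nM, between 0.8 nM and 8 nM, meaning an estimated 6.0-fold lower number from compound 3 to compound 4 (0.78 log units; beyond the scatter).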

Compound 4, inhibition constant: 3.58 nM
For compound 4 the middle estimate is 1.4-fold (0.16 log units) below the measured one; the measured number falls inside the stated range.
By their numbers in this assay, from the lowest: compound 4; then compounds 2 and 3 (each within the scatter of the next); then compound 1.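

In this assay, hydroxymethyl in place of hydrogen on an aromatic carbon, para to a large group, also lowers the number on the core carrying furan-2-yl, a 4.2-fold lower number from compound 3 to compound 4 (0.62 log units; beyond the scatter), and the step agrees with the earlier one on the phenyl-bearing core: the same change on two cores in this assay, a 10-fold lower number (1.01 log units; beyond the scatter) from compound 1 to compound 2 and a 4.2-fold lower number (0.62 log units; beyond the scatter) from compound 3 to compound 4, 2.4-fold (0.39 log units) apart, within the scatter of two such steps. Furan-2-yl in place of phenyl likewise still lowers the number with hydroxymethyl present, a 2.3-fold lower number from compound 2 to compound 4 (0.36 log units; beyond the scatter), and again the two steps agree: the same change on two cores in this assay, a 5.6-fold lower number (0.75 log units; beyond the scatter) from compound 1 to compound 3 and a 2.3-fold lower number (0.36 log units; beyond the scatter) from compound 2 to compound 4, 2.4-fold (0.39 log units) apart, within the scatter of two such steps. The two changes therefore combine on one core.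

The compounds shown leave open whether the hydroxyl matters, which a methyl or methoxy group would test. They also leave open how a longer chain, an amine or a carboxylic acid would fare at this position.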